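The compounds below may be only part of what the source reports. "The series", "measured", "known", "first", "only" and "open" are said of these compounds alone.

Compounds measured so far:

Compound 1, `O=C(NC1CC1)N1CCC(c2cnccc2-c2ccccc2)CC1`, gives 950 nM in an assay on HEK293F cells for inhibition of cholesterol 24-hydroxylase (Homo sapiens), read by trypan blue exclusion, with stated times of 15 min and 5 h; on this read-out lower numbers stand for stronger inhibition and higher numbers for weaker inhibition.
Compound 2, `O=C(NC1CC1)c1ccc(-c2cnccc2-c2ccccc2)cc1`, gives 74 nM in this assay.
Compound 3, `O=C(NC1CC1)C1CCN(c2cnccc2-c2ccccc2)CC1`, gives 8.1 nM in this assay.

Of these three numbers, compound 3 stands lowest. Its nearest neighbour is compound 2, whose number lies beyond the scatter of repeated measurements above it, and compound 1 lies farther still, also beyond the scatter. Compound 3 is therefore the most potent of the three in this assay. Among the measured compounds shown here, no two of the measured compounds differ in only one place, so no single step between them can be described; the three values simply show that the arrangement in compound 3 gives the lowest number.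

Compound 4, `O=C(NC1CC1)C1CCN(c2cnccc2-c2ccccn2)CC1`, has not yet been measured. It differs from compound 3 in one place: pyridin-2-yl in place of phenyl on an aromatic carbon. For the measured compounds named here, no measured pair illustrates this kind of exchange, so the expectation rests on compound 3 alone and on the size of the change, which is small in atom count. The estimate allows for a step in either direction but treats a modest weakening as somewhat more likely than a strengthening.

Compound 4 is expected to give about 15 nM in this assay, within a range of 4 nM to 60 nM, which corresponds to an estimated 1.9-fold higher number from compound 3 to compound 4 (0.27 log units; within the scatter).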

Compound 4, half-maximal inhibitory concentration in the cholesterol 24-hydroxylase assay: 160 nM
For compound 4 the middle estimate is 11-fold (1.03 log units) below the measured one, and the stated range ends below it.
By their numbers in the cholesterol 24-hydroxylase assay, from the lowest: compound 3; then compound 2; then compound 4; then compound 1.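

Among the compounds shown here, the exchange of phenyl for pyridin-2-yl gives the first step that can be read at a single place, and in the cholesterol 24-hydroxylase assay it is large: a 20-fold higher number from compound 3 to compound 4 (1.30 log units; beyond the scatter). This position, ortho to a large group, is therefore far from indifferent to a change that keeps the ring size and the heavy-atom count, and that brings in a ring nitrogen as a hydrogen-bond acceptor. In a physicochemical assay for lipophilicity, at pH 7.4 (a lower number here means a more polar compound, a higher number a more lipophilic compound), compound 3 gives 2.5 and compound 4 gives 1.3. In the physicochemical assay the same exchange also makes the compound more polar, so that weaker inhibition and lower lipophilicity arrive together in this pair: the measured distribution coefficient of compound 3, 2.5, and of compound 4, 1.3, a number 1.20 log units lower (beyond the scatter).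

From the compounds shown here alone, a single pair cannot separate the two changes, so it remains open whether the higher number in the cholesterol 24-hydroxylase assay follows the lower distribution coefficient or the ring nitrogen at this particular place. Pyridin-3-yl, pyridin-4-yl or a phenyl carrying a fluorine or a methoxy group are not among the compounds shown, and any of them at this position would be needed to tell how much of the step depends on where the nitrogen sits.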